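Adding 4-bromophenyl to the chain of compound 2

The compounds below may be only part of what the source reports. "The series", "measured", "known", "first", "only" and "open" are said of these compounds alone.

Measured in a functional assay on K562 cells (Homo sapiens) for cytotoxicity, read by trypan blue exclusion, with a stated time of 96 h; a lower number here means a stronger inhibitor, a higher number a weaker inhibitor:
compound 1 `COc1cc(OC)c(/C=C/S(=O)(=O)Nc2ccc(OC)c([N+](=O)[O-])c2)c(OC)c1` gives 1000 nM
compound 2 `COC(=O)CNc1cc(NS(=O)(=O)/C=C/c2c(OC)cc(OC)cc2OC)ccc1OC` gives 350 nM

Of these two, compound 2 has the lower number. Among the measured compounds shown here, the only measured step is a 2.9-fold lower number from compound 1 to compound 2 (0.46 log units; beyond the scatter), which is modest but beyond the scatter. Compound 3 `COC(=O)C(Nc1cc(NS(=O)(=O)/C=C/c2c(OC)cc(OC)cc2OC)ccc1OC)c1ccc(Br)cc1` has not yet been measured. It differs from compound 2 by 4-bromophenyl in place of hydrogen on a saturated chain carbon bound to a carbonyl carbon and a nitrogen on an aromatic ring, so that (methoxycarbonyl)methyl becomes (4-bromophenyl)(methoxycarbonyl)methyl.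

The measured step bears on this change only indirectly. For the measured compounds named here, it brought in the (methoxycarbonyl)methyl amino chain in place of nitro, and no measured compound carries anything further on that chain carbon. The data therefore give no direction for the new change. The starting point remains compound 2 at 350 nM and a shift of similar modest size either way cannot be excluded. In this assay the expected step is a 1.2-fold lower number from compound 2 to compound 3 (0.07 log units; within the scatter), which means no expected change beyond the scatter. For compound 3 the estimated value is 300 nM, with an expected range from 70 nM to 1300 nM.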

Compound 3, half-maximal inhibitory concentration: 1000 nM
The estimate for compound 3 lay 3.3-fold (0.52 log units) below the measured number; the measured number falls inside the stated range.
By their numbers in this assay, from the lowest: compound 2; then compounds 1 and 3 (each within the scatter of the next).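

In this assay, the saturated chain carbon bound to a carbonyl carbon and a nitrogen on an aromatic ring proves sensitive to substitution: 4-bromophenyl in place of hydrogen there brings a 2.9-fold higher number from compound 2 to compound 3 (0.46 log units; beyond the scatter), a modest step. Among the compounds shown here, the earlier step, a 2.9-fold lower number from compound 1 to compound 2 (0.46 log units; beyond the scatter), concerned only the exchange of nitro for the ((methoxycarbonyl)methyl)amino group, so this is the first direction seen for a change on the chain carbon itself, and it leaves compound 2, with hydrogen at that carbon, with the lowest number of the three. Nothing available here explains why the number rises with this change.

The compounds shown leave open whether the step belongs to the phenyl ring or to its bromine, and whether a smaller group on the same carbon, such as methyl, or a phenyl without bromine would give a similar number. They also leave open how a carboxylic acid in place of the methyl ester would behave, either with or without the 4-bromophenyl group on the chain.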